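Working notes: cyano in place of bromo, compound 3 to compound 4

A few compounds are considered here, and "the series" means these few. Any claim that something is new, unique, unknown or untested is made for them only; others in the source may bear on it.

Measured so far:
compound 1, `O=C(CCC1=CCN(CCCc2ccc(Br)cc2)C1=O)NO`: 2520 nM in a functional assay on NCI-H23 cells (Homo sapiens) for inhibition, read by sulforhodamine B assay; a lower number here means a stronger inhibitor of growth, a higher number a weaker inhibitor of growth
compound 2, `CCOc1ccc(CCCN2CC=C(CCC(=O)NO)C2=O)cc1`: 2520 nM in this assay
compound 3, `O=C(CCC1=CCN(Cc2cccc(Br)c2)C1=O)NO`: 2500 nM in this assay

Compound 3 gives the lowest of the three numbers, but its gaps to compound 1 and to compound 2 are within the scatter, so the three stand level. Compound 4, `N#Cc1cccc(CN2CC=C(CCC(=O)NO)C2=O)c1`, differs from compound 3 by cyano in place of bromo on an aromatic carbon. Among the measured compounds shown here, the only measured step of a related kind, no change at the digits printed from compound 1 to compound 2 (within the scatter), swaps one aromatic substituent for another without moving the number; no measured step exchanges bromo for cyano. On that basis no step beyond the scatter is expected in this assay, that is no change at the digits printed from compound 3 to compound 4 (within the scatter). Compound 4 is estimated at 2500 nM, with an expected range of 1200 nM to 5200 nM.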

Compound 4, concentration for 50% growth inhibition: 4080 nM
The estimate for compound 4 lay 1.6-fold (0.21 log units) below the measured number; measured number inside the range.
By their numbers in this assay, from the lowest: compounds 3, 1, 2 and 4 (each within the scatter of the next).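

In this assay, cyano in place of bromo on an aromatic carbon, meta to a large group, gives a 1.6-fold higher number from compound 3 to compound 4 (0.21 log units; within the scatter) as its step. At this place, then, bromo can give way to cyano, which adds a hydrogen-bond acceptor and a triple bond, without the number leaving the scatter. No measurement on hand explains the result.

On these data alone, it remains open whether an amine or a carboxylic acid on this carbon would also stay within the scatter. Also open, as far as these compounds go, is whether the same exchange in compound 1 would read alike.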